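From 3-bromophenyl to 4-methoxyphenyl on the shared core

The source may report more compounds than this note shows. Statements on the series, on what has been measured and on what is new or still open speak of the compounds shown alone.

In a functional assay on MCF7 cells (Homo sapiens) for antiproliferative activity, read by sulforhodamine B assay, with a stated time of 48 h (on this read-out lower numbers stand for stronger inhibition and higher numbers for weaker inhibition), compound 1 `CCc1ccccc1OS(=O)(=O)c1ccc(N2CCN(C)C2=O)cc1` gives 26000 nM, compound 2 `COc1cccc(OS(=O)(=O)c2ccc(N3CCN(C)C3=O)cc2)c1` gives 3000 nM and compound 3 `CN1CCN(c2ccc(S(=O)(=O)Oc3cccc(Br)c3)cc2)C1=O` gives 1500 nM. Compound 3 thus stands level with compound 2 within the scatter, and both lie well under compound 1. Compound 4 `COc1ccc(OS(=O)(=O)c2ccc(N3CCN(C)C3=O)cc2)cc1` carries 4-methoxyphenyl in place of 3-bromophenyl on an oxygen. The closest evidence is a 2.0-fold lower number from compound 2 to compound 3 (0.30 log units; within the scatter), a swap of bromo for methoxy. Larger changes came with leaving 2-ethylphenyl: an 8.7-fold lower number from compound 1 to compound 2 (0.94 log units; beyond the scatter) and a 17-fold lower number from compound 1 to compound 3 (1.24 log units; beyond the scatter). For the measured compounds named here, no measured compound carries 4-methoxyphenyl, so no step beyond the scatter is expected in this assay. The estimated step is a 2.0-fold higher number from compound 3 to compound 4 (0.30 log units; within the scatter). Compound 4 is expected at 3000 nM, within an estimated range of 800 nM to 11000 nM.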

Compound 4, half-maximal inhibitory concentration: 95000 nM
Compound 4: the middle estimate sits 32-fold (1.50 log units) below what was measured; measured number above the stated range.
By their numbers in this assay, from the lowest: compounds 3 and 2 (each within the scatter of the next); then compound 1; then compound 4.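

Moving the methoxy group alone, from 3-methoxyphenyl to 4-methoxyphenyl, costs far more than the swap of bromo for methoxy did, with a 32-fold higher number from compound 2 to compound 4 (1.50 log units; beyond the scatter) and, against the bromo compound, a 63-fold higher number from compound 3 to compound 4 (1.80 log units; beyond the scatter). Among these compounds, then, where the substituent sits on the phenyl group on this oxygen matters more than which of the two substituents it is, and 4-methoxyphenyl even falls behind 2-ethylphenyl, with a 3.7-fold higher number from compound 1 to compound 4 (0.56 log units; beyond the scatter). Nothing shown here accounts for this drop. From the compounds shown here alone, whether 4-bromophenyl or a phenyl group bearing an amine would fall as far remains open.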